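Swapping the amide aryl group in a benzimidazole carboxamide series

The compounds below may be only part of what the source reports. "The series", "measured", "known", "first", "only" and "open" are said of these compounds alone.

Measured so far in an ADME assay on Vero cells (Chlorocebus sabaeus) for cytotoxicity; on this read-out higher numbers stand for lower toxicity in this test and lower numbers for higher toxicity in this test:
- compound 1, `Cc1csc(NC(=O)c2cccc3[nH]c(-c4cccnc4)nc23)n1`, gives 111 uM
- compound 2, `COc1ccc(-c2nc3c(C(=O)Nc4ccccc4F)cccc3[nH]2)cc1OC`, gives 24.5 uM
- compound 3, `COc1ccc(-c2nc3c(C(=O)Nc4ccccc4F)cccc3[nH]2)c(OC)c1OC`, gives 37.8 uM

Among these three numbers compound 3 stands second highest. For the measured compounds named here, its nearest neighbour is compound 2, and the only single-point step in the set, a 1.5-fold higher number from compound 2 to compound 3 (0.19 log units; within the scatter), stays within the scatter. Going by the values given here, compound 1 sits further off, a gap beyond the scatter, but it differs from compound 3 in more than one place, so no single step links them.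

Compound 4, `COc1ccc(-c2nc3c(C(=O)Nc4nc5ccccc5[nH]4)cccc3[nH]2)c(OC)c1OC`, arises from compound 3 by the change (1H-benzimidazol-2-yl in place of 2-fluorophenyl on an amide-type nitrogen). Among the compounds with values here, none of the measured steps touches the group on the amide nitrogen, so nothing here tells how large a step to expect in this assay, or in which direction. The cautious expectation is therefore no step beyond the scatter: compound 4 is estimated at 40 uM, with a range from 15 uM to 110 uM, which means an expected step of a 1.1-fold higher number from compound 3 to compound 4 (0.02 log units; within the scatter).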

Compound 4, half-maximal toxic concentration: 29 uM
Estimate against measurement, compound 4: 1.4-fold (0.14 log units) above; the measured number falls inside the stated range.
By their numbers in this assay, from the lowest: compounds 2, 4 and 3 (each within the scatter of the next); then compound 1.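

For the compounds shown here, the group on the amide nitrogen changes here for the first time in the set, and in this assay the swap gives a 1.3-fold lower number from compound 3 to compound 4 (0.12 log units; within the scatter). So 1H-benzimidazol-2-yl, with its second ring and its hydrogen-bond donor and acceptor, can replace 2-fluorophenyl on this nitrogen with no shift beyond the scatter in this test, at least with the shared core of compound 3 and compound 4. None of the data shown explains this outcome.

As far as these compounds go, how a plain phenyl, a pyridine ring or a short alkyl chain on this nitrogen would read stays open. From the compounds shown here alone, it is also open whether the same swap behaves alike with a different group on the other side of the core; compound 1 differs from compound 4 in more than one place and cannot answer that.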